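Vinyl for iodo on a selenium-containing fused ring

A few compounds are considered here, and "the series" means these few. Any claim that something is new, unique, unknown or untested is made for them only; others in the source may bear on it.

Compound 1, `C#Cc1ncccn1`: > 40000 nM (a limit of the assay).
Compound 2, `Ic1nc2ccccc2[se]1`: > 40000 nM (a limit of the assay).

In a functional assay on NCI-H522 cells (Homo sapiens) for cytotoxicity, with a stated time of 3 days (on this read-out higher numbers stand for weaker inhibition and lower numbers for stronger inhibition), compound 2 gives only a limit, > 40000 nM, not a number. Compound 1 likewise stands at a limit. Both values sit at the limit of > 40000 nM in this assay, at which 2 of the 2 values shown sit, so nothing shows which is stronger. Compound 3, `C=Cc1nc2ccccc2[se]1`, differs from compound 2 in one place: vinyl in place of iodo on an aromatic carbon. Among the compounds with values here, no measured step is available, so compound 3 is expected to stay near the same limit, with the step of a number no higher from compound 2 to compound 3 (the limit leaves the size open) estimated as none beyond the scatter. Compound 3 is estimated at 40000 nM, between 12000 nM and 120000 nM.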

Compound 3, half-maximal inhibitory concentration: 12200 nM
Compound 3: middle estimate off by 3.3-fold (0.52 log units), on the high side; measured number inside the range.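

In this assay, vinyl in place of iodo on this aromatic carbon, next to the ring nitrogen and the ring selenium, gives an at least 3.2-fold lower number from compound 2 to compound 3 (0.51 log units; beyond the scatter). Within the data shown here, compound 3 is thus the first compound here with a real number, so a change at this position can register in this assay. Compound 2 stands at a limit, so the full size of the step stays unknown: the limit of > 40000 nM in this assay, at which 2 of the 3 values shown sit.

The compounds shown leave open how an ethyl group, an amine or a carboxylic acid would read in this place. It therefore remains unclear whether the change goes with the vinyl double bond or simply with the loss of iodo.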